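The source may report more compounds than this note shows. Statements on the series, on what has been measured and on what is new or still open speak of the compounds shown alone.

Of the compounds shown here, three have been measured so far in a functional assay on RKO cells (Homo sapiens) for inhibition, read by MTT assay, with a stated time of 48 h; a lower number here means a stronger inhibitor, a higher number a weaker inhibitor. Compound 2 `C[Se]c1ccc(N(C)c2nc(C3CC3)nc3ccccc23)cc1` gives the lowest number (21 nM), compound 1 `COc1ccc(N(C)c2nc(C)nc3ccccc23)cc1OCCC[Se]C#N` gives a higher one (799 nM), and compound 3 `COc1ccc(N(C)c2nc(C)nc3ccccc23)cc1C(=O)OCC[Se]C#N` gives the highest of the three (2390 nM). That makes compound 3 the weakest inhibitor of this small set.

Compound 4 `COc1ccc(N(C)c2nc(C)nc3ccccc23)cc1C(=O)OCCC[Se]C#N` differs from compound 3 in one place (a group of 4 heavy atoms (2 carbon, 1 nitrogen, 1 selenium; no ring) in place of a group of 3 heavy atoms (1 carbon, 1 nitrogen, 1 selenium; no ring), on a saturated chain carbon, two bonds along the chain from an oxygen next to a carbonyl group). For the measured compounds named here, no measured pair shows this change on its own. Going by the values given here, the only measured step close to it is a 3.0-fold higher number from compound 1 to compound 3 (0.48 log units; beyond the scatter) and that step is modest. It exchanges a whole group on an aromatic carbon, so it cannot show what the present change does alone. It does show that a larger exchange in this part of the structure moved the number only a little. Compound 2 differs from compound 3 in more than one place, so its much lower number offers no guide here.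

A small step is therefore expected in this assay, with no firm direction and no move beyond the scatter. The estimated step is small (a 1.2-fold lower number from compound 3 to compound 4 (0.08 log units; within the scatter)). For compound 4 the expected value is 2000 nM with an estimated range from 800 nM to 5000 nM in this assay.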

Compound 4, half-maximal inhibitory concentration: 1140 nM
The estimate for compound 4 lay 1.8-fold (0.24 log units) above the measured number; measured number inside the range.
By their numbers in this assay, from the lowest: compound 2; then compounds 1 and 4 (each within the scatter of the next); then compound 3.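

In this assay, for the compounds shown here, adding to the saturated chain, two bonds along the chain from an oxygen next to a carbonyl group, gives a 2.1-fold lower number from compound 3 to compound 4 (0.32 log units; beyond the scatter), the first reading of this change on its own; the step is modest but lies beyond the scatter, so the chain at this position has a measurable, if limited, influence on the number. The larger exchange on the aromatic carbon now reads differently: at the shorter chain it gave a 3.0-fold higher number from compound 1 to compound 3 (0.48 log units; beyond the scatter), beyond the scatter, whereas at the longer chain it gives a 1.4-fold higher number from compound 1 to compound 4 (0.15 log units; within the scatter), within the scatter, so the effect of that exchange depends on the chain that comes with it. Nothing shown gives a measured reason for either result.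

Going by these compounds, with only these two chain lengths on the carbonyl-bearing group, it remains open whether a longer chain would lower the number further or raise it again. On these data alone, it is also open how the number would respond to an amine at the end of this chain in place of the selenium and nitrile.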